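The source may hold more compounds than are shown below. What is called first, only, known or untested is meant among the compounds shown, and "the series" means these compounds.

The series rests on one shared core, carried in compound 1 `CNc1ncnc2c1c(-c1ccccc1)cn2[C@@H]1O[C@H](CO)[C@@H](O)[C@H]1O`, compound 2 `CNc1ncnc2c1c(-c1ccoc1)cn2[C@@H]1O[C@H](CO)[C@@H](O)[C@H]1O` and compound 3 `CN(C)c1ncnc2c1c(-c1cc3ccccc3o1)cn2[C@@H]1O[C@H](CO)[C@@H](O)[C@H]1O`. In a functional assay on CCRF-CEM cells (Homo sapiens), read by MTT assay, with a stated time of 72 h (on this read-out lower numbers stand for stronger inhibition and higher numbers for weaker inhibition), compound 1 gives only a limit of the assay, > 20000 nM. Compound 2 likewise returns only a limit in this assay, > 20000 nM. The step that the two limits leave unreadable from compound 1 to compound 2 is therefore unreadable. Compound 3 also returns only a limit in this assay, > 20000 nM, and so it stands with the other two at the limit of > 20000 nM in this assay, at which 3 of the 3 values shown sit, with no numbered value anywhere among the three.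

Compound 4 `CNc1ncnc2c1c(-c1cc3ccccc3o1)cn2[C@@H]1O[C@H](CO)[C@@H](O)[C@H]1O` differs from compound 3 in one place: hydrogen in place of methyl on a nitrogen on an aromatic ring. No measured step bears on this change; the only step shown, that from phenyl to furan-3-yl, is itself unreadable. With every value sitting at the limit, the expectation for compound 4 is that it too will return only a limit in this assay, and the step that the limit leaves unreadable from compound 3 to compound 4 is estimated as none beyond the scatter. Compound 4 is thus expected at about 30000 nM, in a range from 10000 nM to 100000 nM.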

Compound 4, half-maximal inhibitory concentration: > 20000 nM
Compound 4: a limit, no number; the forecaster's own chance of this, stated with the estimate: 80%; the middle value lies beyond the limit too.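

Compound 4 returns only a limit, like compound 1, compound 2 and compound 3, so no step among these compounds can be read in this assay: the limit of > 20000 nM in this assay, at which 4 of the 4 values shown sit.

The compounds shown leave open whether either change, on the aromatic carbon or on the nitrogen, alters inhibition at all.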